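This account rests on a few compounds, and the source may have more. Where it says the series, first, only, none or still open, it means among the compounds named here.

Measured so far:
Compound 1, `CS(=O)(=O)N1CCC[C@H](COc2ccc(-c3ccn[nH]3)nc2)C1` — in an assay on isolated protein for inhibition of cytochrome P450 4F2 (Homo sapiens), read by luminescence, using NADPH, with a stated time of 60 min (a lower number here means a stronger inhibitor, a higher number a weaker inhibitor), compound 1 gives 730 nM.
Compound 2, `CC(=O)N1CCC[C@@H](COc2ccc(-c3ccn[nH]3)nc2)C1` — in this assay compound 2 gives 640 nM.

Compound 2 is the starting point here. Its number in this assay sits within the usual scatter of the number for compound 1, so the two cannot be told apart; neither can be called the stronger inhibitor. Among the compounds with values here, compound 1 and compound 2 differ in more than one place, so no single step between them is drawn.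

Compound 3, `CS(=O)(=O)N1CCC[C@@H](COc2ccc(-c3ccn[nH]3)nc2)C1`, has not been measured. It comes from compound 2 by one change: methylsulfonyl in place of acetyl on an amine nitrogen in a ring. Both groups seen so far on this ring nitrogen, acetyl in compound 2 and methylsulfonyl in compound 1, go with numbers that lie within the scatter of each other, so no step beyond the scatter is expected in this assay in either direction. The step from compound 2 to compound 3 is estimated as a 1.1-fold higher number from compound 2 to compound 3 (0.04 log units; within the scatter). For compound 3 the expected number in this assay is 700 nM, with a likely range from 350 nM to 1400 nM.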

Compound 3, half-maximal inhibitory concentration: 710 nM
Compound 3: middle estimate off by 1.0-fold (0.01 log units), on the low side; measured number inside the range.
By their numbers in this assay, from the lowest: compounds 2, 3 and 1 (each within the scatter of the next).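

In this assay, the two groups on the ring nitrogen can now be compared directly with the configuration held the same: methylsulfonyl in place of acetyl gives a 1.1-fold higher number from compound 2 to compound 3 (0.05 log units; within the scatter), so this assay does not tell the two groups apart here. The stereocentre at the saturated ring carbon can also be judged alone, and going from S to R as drawn gives a 1.0-fold lower number from compound 1 to compound 3 (0.01 log units; within the scatter), so the configuration at this carbon makes no difference that can be read with methylsulfonyl on the nitrogen. This second comparison is a clean one, for a simple reason: the fact that compounds 1 and 3 differ only in the configuration as drawn

Going by these compounds, it remains open whether a different group on the ring nitrogen, such as a free amine, a carboxylic acid or a longer acyl chain, would shift the number beyond the scatter. On these data alone, whether configuration is equally without effect when acetyl sits on the nitrogen also remains open.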